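A few compounds are considered here, and "the series" means these few. Any claim that something is new, unique, unknown or untested is made for them only; others in the source may bear on it.

The measured compounds:

Compound 1 `O=C1C(Nc2ccc(I)cc2)=CC(=O)c2c1nc1n2[C@H]2OC[C@@H](O)[C@H]2OC1`. In a functional assay on MGC-803 cells (Homo sapiens) for inhibition, read by sulforhodamine B assay (a higher number here means a weaker inhibitor, a lower number a stronger inhibitor), compound 1 gives 2150 nM.

Compound 2 `O=C1C=C(N2CCCCC2)C(=O)c2c1nc1n2[C@H]2OC[C@@H](O)[C@H]2OC1`. In this assay compound 2 gives > 8000 nM, which is a limit of the assay rather than a number.

Among the measured compounds shown here, compound 1 therefore carries the only numerical value in this small set; the remaining entry is the limit of > 8000 nM in this assay, at which 1 of the 2 values shown sits, so no comparison of size can be drawn from compound 2 beyond noting that it did not reach a measurable value.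

Compound 3 `CCOc1ccccc1NC1=CC(=O)c2c(nc3n2[C@H]2OC[C@@H](O)[C@H]2OC3)C1=O` has not yet been measured. It differs from compound 1 in one place only: 2-ethoxyphenyl in place of 4-iodophenyl on an amine nitrogen. For the measured compounds named here, since no pair of measured compounds shares this kind of change, there is no measured step to lean on, and the direction of the change is open. The expectation is that the step from compound 1 to compound 3 stays modest, a 1.4-fold higher number from compound 1 to compound 3 (0.14 log units; within the scatter), leaning if anything toward a weaker value but with a real chance of landing within the usual scatter. On that basis compound 3 is estimated at 3000 nM, with a range from 1000 nM to 9000 nM.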

Compound 3, half-maximal inhibitory concentration: 2830 nM
Estimate against measurement, compound 3: 1.1-fold (0.03 log units) above; measured number inside the range.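

In this assay, putting 2-ethoxyphenyl in place of 4-iodophenyl on the amine nitrogen gives a 1.3-fold higher number from compound 1 to compound 3 (0.12 log units; within the scatter), so the two compounds cannot be told apart at this level of precision. Among the compounds shown here, this is the first step that can be read at this position, and it shows that two quite different substituted phenyl groups, one carrying iodine and the other an oxygen-linked ethyl chain, can sit on this nitrogen with no change beyond the scatter. Nothing shown gives a reason for this result.

On these data alone, what remains open is how much of the activity depends on the aromatic ring on this nitrogen at all, since both compounds compared here carry a substituted phenyl, and it is unknown how a plain phenyl, a benzyl group or a simple alkyl chain would read in this position. The step also exchanges the substituent and its place on the ring together, so the compounds shown cannot separate the two, and a 4-ethoxyphenyl or 2-iodophenyl group would be needed to tell them apart.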